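A few compounds are considered here, and "the series" means these few. Any claim that something is new, unique, unknown or untested is made for them only; others in the source may bear on it.

Working notes on the series. Compound 1 `CC(C)CCOc1cc(C(F)(F)F)ccc1CNC(=O)C(C)c1ccc(NS(C)(=O)=O)c(F)c1` and compound 2 `CC(C(=O)NCc1ccc(C(F)(F)F)cc1SC1CCCCC1)c1ccc(NS(C)(=O)=O)c(F)c1` share one core and differ only in the group on an aromatic carbon, isopentyloxy in compound 1 against cyclohexylsulfanyl in compound 2. In an assay on CHO cells for antagonist activity at transient receptor potential cation channel subfamily V member 1 (Homo sapiens), read by FLIPR (on this read-out higher numbers stand for weaker inhibition and lower numbers for stronger inhibition), compound 1 gives 0.5 nM and compound 2 gives 0.5 nM; the step of no change at the digits printed from compound 1 to compound 2 (within the scatter) lies within the scatter, so compound 2 stands level with compound 1 on the numbers available.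

Compound 3 `CC(C(=O)NCc1ccc(C(F)(F)F)cc1SCc1ccco1)c1ccc(NS(C)(=O)=O)c(F)c1` is not yet measured. The change is (furan-2-yl)methyl in place of cyclohexyl on a sulfur, that is, cyclohexylsulfanyl to ((furan-2-yl)methyl)sulfanyl. Among the compounds with values here, only one measured step exists, no change at the digits printed from compound 1 to compound 2 (within the scatter), and it concerns the whole group on that aromatic carbon rather than the group on the sulfur; no measured step varies the substituent on the sulfur itself. That step was flat, so a step of a 2.0-fold higher number from compound 2 to compound 3 (0.30 log units; within the scatter) is expected, at most a small loss. For compound 3 in this assay a value of 1 nM is estimated, with a range from 0.3 nM to 4 nM.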

Compound 3, inhibition constant: 3.2 nM
For compound 3 the middle estimate is 3.2-fold (0.51 log units) below the measured one; the range from low to high includes it.
By their numbers in this assay, from the lowest: compounds 1 and 2 (each within the scatter of the next); then compound 3.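

In this assay, within the data shown here, the substituent on the sulfur is not neutral: with (furan-2-yl)methyl in place of cyclohexyl, the step of a 6.4-fold higher number from compound 2 to compound 3 (0.81 log units; beyond the scatter) is the first to pass beyond the scatter. Against the isopentyloxy group the picture is the same, with a 6.4-fold higher number from compound 1 to compound 3 (0.81 log units; beyond the scatter) as a modest loss, so the flat result for the first two compounds does not extend to every group at this aromatic carbon. No evidence at hand bears on the reason for this loss.

The compounds shown leave open whether the loss follows the furan ring or the methyl link, since both enter together; benzyl or cyclohexylmethyl on the sulfur would separate the two. Also open, as far as these compounds go, is how the (furan-2-yl)methyl group behaves when joined through an ether oxygen rather than through sulfur.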